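The source may report more compounds than this note shows. Statements on the series, on what has been measured and on what is new or still open speak of the compounds shown alone.

Measured in a functional assay on HEK293 cells (Homo sapiens) for cytotoxicity; on this read-out higher numbers stand for lower toxicity in this test and lower numbers for higher toxicity in this test:
- compound 1 `CCCCNc1cccc(N2C[C@@H](c3ccc(OC)c(OC4CCCC4)c3)CC2=O)c1`: > 10000 nM, a limit
- compound 2 `COc1ccc(S(=O)(=O)Nc2cccc(N3C[C@@H](c4ccc(OC)c(OC5CCCC5)c4)CC3=O)c2)cc1`: > 10000 nM, a limit
- compound 3 `COc1ccc([C@H]2CC(=O)N(c3cccc(NS(=O)(=O)c4cccc(Cl)c4C)c3)C2)cc1OC1CCCC1`: > 10000 nM, a limit

In this assay compound 3 gives only a limit, not a number, and it shares this position with the other two compounds: the limit of > 10000 nM in this assay, at which 3 of the 3 values shown sit.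

Compound 4 `COc1ccc([C@H]2CC(=O)N(c3cccc(NS(=O)(=O)c4ccccc4F)c3)C2)cc1OC1CCCC1` carries 2-fluorophenyl in place of 3-chloro-2-methylphenyl on a sulfonyl sulfur.

The closest measured change is also on a sulfonyl sulfur: a step that the two limits leave unreadable from compound 2 to compound 3. The two changes on the nitrogen give no size either: a step that the two limits leave unreadable from compound 1 to compound 2, and a step that the two limits leave unreadable from compound 1 to compound 3. These steps therefore supply no size and no direction. No step beyond the scatter is expected for a step that the limit leaves unreadable from compound 3 to compound 4, since compound 3 and compound 2 both rest at the same limit, (the limit of > 10000 nM in this assay, at which 3 of the 3 values shown sit). A further limit is the most likely report for the new compound. The estimated value for compound 4 is 15000 nM. The expected range for compound 4 runs from 8000 nM to 30000 nM.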

Compound 4, half-maximal cytotoxic concentration: > 10000 nM
Compound 4 gave a limit, no number (the forecaster's own chance of this, stated with the estimate: 90%); the middle value does not contradict the limit.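

Compound 4 gives only a limit, not a number, in this assay, so its steps from compound 1, compound 2 and compound 3 cannot be read: the limit of > 10000 nM in this assay, at which 4 of the 4 values shown sit.

The compounds shown leave open whether any change on the sulfonyl sulfur or on the nitrogen alters the result in this assay.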